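Swapping Trifluoromethyl for Methyl in a Growth Inhibition Series

This account rests on a few compounds, and the source may have more. Where it says the series, first, only, none or still open, it means among the compounds named here.

Values from a functional assay on IGROV-1 cells (Homo sapiens) for inhibition (on this read-out lower numbers stand for stronger inhibition of growth and higher numbers for weaker inhibition of growth), so far:
- compound 1 `Cc1cc(-c2nc3c(F)cccc3s2)ccc1N` gives 22900 nM
- compound 2 `Cc1cc(-c2nc3ccc(F)cc3s2)ccc1N` gives 1300 nM
- compound 3 `Nc1ccc(-c2nc3ccccc3s2)cc1C(F)(F)F` gives 2600 nM

Compound 2 (1300 nM) and compound 3 (2600 nM) lie within the scatter of each other. Compound 3 (2600 nM) has a much lower number than compound 1 (22900 nM), a gap well beyond the scatter.

The open question is compound 4 `Cc1cc(-c2nc3ccccc3s2)ccc1N`, which has methyl in place of trifluoromethyl on an aromatic carbon of compound 3 (methyl in place of trifluoromethyl on an aromatic carbon). Going by the values given here, no measured pair isolates this swap, so the expectation is loose. Compound 1 and compound 2 carry the same methyl as compound 4, together with a fluorine on the core that compound 4 lacks. Among the compounds with values here, their values show only that methyl compounds can differ widely here. Even so, compound 2 (1300 nM) shows that a methyl compound can match compound 3, and the unfluorinated core may do better. A shift to a lower number, beyond the scatter, is therefore expected, with an estimated size of an 8.7-fold lower number from compound 3 to compound 4 (0.94 log units; beyond the scatter) in this assay. For compound 4 the estimated value is 300 nM, with an expected range from 15 nM to 2500 nM.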

Compound 4, concentration for 50% growth inhibition: < 10 nM
Compound 4: no number, only a limit; the forecaster's own chance of this, stated with the estimate: 10%; at least 30-fold (1.47 log units) between middle value and limit.
By their numbers in this assay, from the lowest: compounds 2 and 3 (each within the scatter of the next); then compound 1. At a limit, below all of these: compound 4.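

In this assay compound 4 is given only as a limit of the assay, not as a number: the limit of < 10 nM in this assay, at which 1 of the 4 values shown sits.

Going by these compounds alone, this is the first pair to isolate methyl in place of trifluoromethyl on an aromatic carbon ortho to an amino group, and it gives an at least 260-fold lower number from compound 3 to compound 4 (2.41 log units; beyond the scatter), showing that this position responds strongly to the change and that methyl is by far the better of the two groups here. The fluorine on the core also matters in these methyl compounds, since hydrogen in place of fluoro gives an at least 130-fold lower number from compound 2 to compound 4 (2.11 log units; beyond the scatter) and an at least 2200-fold lower number from compound 1 to compound 4 (3.35 log units; beyond the scatter), so both fluorinated compounds lie far from compound 4 wherever the fluorine sits.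

As far as these compounds go, with compound 4 at a limit, the true size of all three steps remains unknown, and they can only be larger than printed. The compounds shown also leave open whether a chloro or an ethyl group on the same carbon would track methyl or trifluoromethyl, and whether a trifluoromethyl compound with a fluorine on the core would follow the same pattern.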